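A few compounds are considered here, and "the series" means these few. Any claim that something is new, unique, unknown or untested is made for them only; others in the source may bear on it.

Compound 1 `COc1cccc(-c2nc3c(=O)[nH]c(C)nc3s2)c1`: 1%
Compound 2 `Cc1cccc(-c2nc3c(=O)[nH]c(C)nc3s2)c1`: 1%

In an assay on CHO cells for displacement of a labelled ligand from adenosine receptor A1 (Homo sapiens), read by scintillation counting, with a stated time of 120 min, tested at 1 uM (on this read-out higher numbers stand for more inhibition at the one concentration tested (going by the name of the read-out) and lower numbers for less inhibition), compound 1 gives 1% and compound 2 gives 1%. Among the compounds with values here, the one measured step, no change at the digits printed from compound 1 to compound 2 (within the scatter), lies within the scatter, so compound 2 stands level with compound 1 on these numbers. Compound 3 `Cc1nc2sc(-c3cccc(F)c3)nc2c(=O)[nH]1` differs from compound 2 by fluoro in place of methyl on an aromatic carbon. Within the data shown here, the only step that bears on this exchange of one small group on the aromatic carbon for another is no change at the digits printed from compound 1 to compound 2 (within the scatter), and it showed nothing beyond the scatter. For compound 3 the expected step in this assay is therefore a number 1 percentage points higher from compound 2 to compound 3 (within the scatter), none beyond the scatter. Compound 3 is estimated at 2%, with a range from -6% to 12%.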

Compound 3, a percentage reported as inhibition, at one concentration (the size of the read-out at that concentration, not a potency): 1%
The estimate for compound 3 lay 1 percentage points above the measured number; the measured number falls inside the stated range.
By their numbers in this assay, from the lowest: compounds 1, 2 and 3 (each within the scatter of the next).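

In this assay the exchange for fluoro at this position gives no change at the digits printed from compound 2 to compound 3 (within the scatter) and no change at the digits printed from compound 1 to compound 3 (within the scatter) so the result now covers fluoro as well as methyl and methoxy. On the aromatic carbon meta to a large group, this exchange of small groups has so far moved the read-out by nothing beyond the scatter. No supporting data bear on this result.

As far as these compounds go, whether an amine, a carboxylic acid or a longer chain on this carbon would give a step beyond the scatter remains open. Also open, from the compounds shown here alone, is whether another place on the shared core would respond to a change.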